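A few compounds are considered here, and "the series" means these few. Any claim that something is new, unique, unknown or untested is made for them only; others in the source may bear on it.

Compound 1, with the structure `CC1=CC[C@H](C(C)(C)NC(=S)N/N=C/c2ccc(O)cc2)CC1`, is one of two analogues of the shared core measured in a functional assay on OVCAR-3 cells (Homo sapiens) for inhibition, read by sulforhodamine B assay, with a stated time of 48 h; on this read-out higher numbers stand for weaker inhibition of growth and lower numbers for stronger inhibition of growth. In this assay compound 1 reaches only a limit of the assay, reported as > 100000 nM. Compound 2, `CC1=CC[C@H](C(C)(C)NC(=S)N/N=C/c2ccc(N(C)C)cc2)CC1`, carries dimethylamino in place of hydroxy on an aromatic carbon. In this assay compound 2 likewise reaches only a limit, > 100000 nM. The step that the two limits leave unreadable from compound 1 to compound 2 therefore cannot be read, since (the limit of > 100000 nM in this assay, at which 2 of the 2 values shown sit). For the measured compounds named here, compound 2 thus stands at a limit, and the one other value shown is a limit as well, so no numbered position is known for it.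

Compound 3, `CC1=CC[C@H](C(C)(C)NC(=S)N/N=C/c2ccc(Cl)cc2)CC1`, differs from compound 2 in one place: chloro in place of dimethylamino on an aromatic carbon. Going by the values given here, the only measured step, a step that the two limits leave unreadable from compound 1 to compound 2, bears on this change insofar as it also exchanges the group on an aromatic carbon, but its size is not readable, so no direction can be drawn from it. With both shown values at a limit, the expectation is that the step of a number no higher from compound 2 to compound 3 (the limit leaves the size open) stays within the scatter. Compound 3 is therefore estimated at 100000 nM in this assay, with a range from 20000 nM to 300000 nM.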

Compound 3, concentration for 50% growth inhibition: 8600 nM
The estimate for compound 3 lay 12-fold (1.07 log units) above the measured number; measured number below the stated range.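

In this assay, the group on this aromatic carbon proves able to move the read-out, which compounds 1 and 2 could not show, since chloro in place of dimethylamino gives an at least 11-fold lower number from compound 2 to compound 3 (1.06 log units; beyond the scatter) and chloro in place of hydroxy gives an at least 11-fold lower number from compound 1 to compound 3 (1.06 log units; beyond the scatter). Both steps are beyond the scatter and point the same way, so the two groups that leave, each attached through a heteroatom, are set apart from chloro, while the step between compound 1 and compound 2 still cannot be read. As far as these compounds go, the true size of both new steps stays open, and each is only a lower bound because compound 1 and compound 2 sit at a limit: the limit of > 100000 nM in this assay, at which 2 of the 3 values shown sit.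

The compounds shown leave open whether this gain belongs to chloro alone or would also appear with fluoro, bromo, methyl or trifluoromethyl on the same carbon. They also leave open whether a nitro group or a methoxy group would behave like chloro or like the hydroxy and dimethylamino groups of compound 1 and compound 2.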